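The source may hold more compounds than are shown below. What is called first, only, known or untested is meant among the compounds shown, and "the series" means these compounds.

Working notes on the series. The shared core of compound 1 `COc1cc(C(=O)C2Sc3nnc(-c4cc(OC)c(OC)c(OC)c4)n3NC2c2ccco2)cc(OC)c1OC` is kept in compound 2 `COc1cc(-c2nnc3n2NC(c2ccco2)C(C(=O)c2ccccc2)S3)cc(OC)c1OC` and compound 3 `COc1cc(-c2nnc3n2NC(c2ccco2)C(C(=O)c2ccc(F)c(F)c2)S3)cc(OC)c1OC`; they differ only in the group on a carbonyl carbon. In a functional assay on HepG2 cells (Homo sapiens) for cytotoxicity, read by MTT assay, with a stated time of 48 h (on this read-out higher numbers stand for weaker inhibition and lower numbers for stronger inhibition), compound 1 gives only a limit, > 100000 nM. Compound 2 gives 90900 nM in this assay. Compound 3 gives 52400 nM in this assay. Compound 3 and compound 2 lie within the scatter of each other: a 1.7-fold lower number from compound 2 to compound 3 (0.24 log units; within the scatter). Against compound 1 only floors can be stated, since the limit of > 100000 nM in this assay, at which 1 of the 3 values shown sits: an at least 1.1-fold lower number from compound 1 to compound 2 (0.04 log units; that floor lies within the scatter) and an at least 1.9-fold lower number from compound 1 to compound 3 (0.28 log units; that floor lies within the scatter).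

Compound 4 `COc1cc(-c2nnc3n2NC(c2ccco2)C(C(=O)c2ccco2)S3)cc(OC)c1OC` is the next member, not yet measured. The change from compound 3 is furan-2-yl in place of 3,4-difluorophenyl on a carbonyl carbon. Going by the values given here, the measured steps that bear on it are the swaps of the group on the carbonyl carbon just noted; none of them reached beyond the scatter, and the one from a plain number to a plain number, a 1.7-fold lower number from compound 2 to compound 3 (0.24 log units; within the scatter), is small. On that basis the expected step in this assay is a 1.1-fold higher number from compound 3 to compound 4 (0.06 log units; within the scatter), that is, no shift beyond the scatter in either direction. Compound 4 is therefore estimated at 60000 nM in this assay, with a range from 25000 nM to 150000 nM.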

Compound 4, half-maximal inhibitory concentration: > 100000 nM
Compound 4: no number, only a limit; the forecaster's own chance of this, stated with the estimate: 25%; at least 1.6-fold (0.22 log units) between middle value and limit.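

In this assay, going by these compounds alone, furan-2-yl brings a five-membered aromatic ring with 1 hetero atom onto the carbonyl carbon, a ring type that the earlier compounds did not place there, and the change can be stated only as floors: an at least 1.9-fold higher number from compound 3 to compound 4 (0.28 log units; that floor lies within the scatter), and an at least 1.1-fold higher number from compound 2 to compound 4 (0.04 log units; that floor lies within the scatter). Within the data shown here, neither floor shows a shift beyond the scatter, so even this change of ring type gives no step at this place that can be called real, although compound 4 now joins compound 1 in giving a limit rather than a number, leaving plain numbers only with the phenyl of compound 2 and the 3,4-difluorophenyl of compound 3. The step between compound 1 and compound 4 cannot be read, because both compounds sit at the limit: the limit of > 100000 nM in this assay, at which 2 of the 4 values shown sit.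

Going by these compounds, how far compound 4 actually lies from compound 3 stays open, as only a floor is available for that step. Also open, on these data alone, is whether an amine, a carboxylic acid or a longer chain on the carbonyl carbon would give a step beyond the scatter in this assay.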